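The source may report more compounds than this note shows. Statements on the series, on what has been measured and on what is new or still open speak of the compounds shown alone.

Working notes on the series in an assay on isolated protein for inhibition of glucose-6-phosphatase catalytic subunit 1 (Homo sapiens), read by inositol phosphate accumulation, with a stated time of 30 min, tested at 100 uM; a lower number here means less inhibition, a higher number more inhibition at the concentration tested (going by the name of the read-out).

Three compounds have numbers or a report so far. Compound 1 `O=C1CCCC2=C1C(c1ccc(F)cc1)C=C(c1ccccc1)N2` gives 21.9% in this assay. Compound 2 `CCOC(=O)C1(O)CC(c2ccc(Br)cc2)C2=C(CC(C)(C)CC2=O)O1` is reported in this assay as "not active" (no number reported), with no number given. Compound 3 `CC1(C)CC(=O)C2=C(C1)NC(c1ccccc1)=CC2c1ccc(Cl)cc1` gives 7.16% in this assay, the lower of the two numbers reported; the gap to compound 1 lies beyond the usual scatter, while compound 2 stands apart without a single number.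

Compound 4 `CC1(C)CC(=O)C2=C(C1)NC(c1ccccc1)=CC2c1ccc([N+](=O)[O-])cc1` has not yet been measured in this assay. It differs from compound 3 in one place: nitro in place of chloro on an aromatic carbon. Going by the values given here, no step between measured compounds covers this exchange, so nothing in the present numbers shows how the assay responds to a nitro group in place of a chloro group on that ring.

Given the low reading of compound 3 7.16% and the absence of any measured step of this kind, the step of a number 4.8 percentage points higher from compound 3 to compound 4 (within the scatter) is expected to be small and not beyond the scatter. Compound 4 is therefore estimated at 12% in this assay, with a range from 0% to 30%.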

Compound 4, a percentage reported as inhibition, at one concentration (the size of the read-out at that concentration, not a potency): "not active" (no number reported)
Nothing numeric was reported for compound 4; there is nothing to compare the estimate with.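

In this assay, going by these compounds alone, compound 4 is reported as "not active" (no number reported), and no step from compound 3 to compound 4 can be read. No further data bear on this result. The compounds shown leave open how far 4-chlorophenyl to 4-nitrophenyl shifts inhibition.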